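Pyrazolone amides: swapping the aryl on the ring nitrogen

The source may hold more compounds than are shown below. What is called first, only, known or untested is meant among the compounds shown, and "the series" means these compounds.

Measured so far in a functional assay on A549 cells (Homo sapiens) for cytotoxicity, read by MTT assay, with a stated time of 72 h; on this read-out higher numbers stand for weaker inhibition and lower numbers for stronger inhibition:
compound 1 `Cc1cc(=O)n(-c2cccc(F)c2)nc1C(=O)Nc1ccc(Oc2ncnc3[nH]ccc23)c(F)c1` — 31500 nM
compound 2 `Cc1cc(=O)n(-c2ccc(Br)cc2F)nc1C(=O)Nc1ccc(Oc2ncnc3[nH]ccc23)c(F)c1` — 6120 nM
compound 3 `Cc1cc(=O)n(-c2ccc(Br)cc2F)nc1C(=O)Nc1ccc(Oc2ncnc3c2ccn3C)cc1` — 47300 nM

Compound 2 and compound 1 share one core and differ only by 3-fluorophenyl in place of 4-bromo-2-fluorophenyl on an aromatic nitrogen. That change gave a 5.1-fold higher number from compound 2 to compound 1 (0.71 log units; beyond the scatter). Compound 3 carries a different core; the difference between the two cores is not broken down here, and its value stands apart from both, within the scatter of compound 1 and beyond it from compound 2.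

Compound 4 `Cc1cc(=O)n(-c2cccc(F)c2)nc1C(=O)Nc1ccc(Oc2ncnc3c2ccn3C)cc1`, not yet measured, arises from compound 3 by 3-fluorophenyl in place of 4-bromo-2-fluorophenyl on an aromatic nitrogen, the same change as from compound 2 to compound 1, at the same place. Transferring that step, the expectation is a 3.8-fold higher number from compound 3 to compound 4 (0.58 log units; beyond the scatter) in this assay, resting on compound 1 and compound 2 with a 5.1-fold higher number from compound 2 to compound 1 (0.71 log units; beyond the scatter). Compound 4 is therefore expected near 180000 nM, between 50000 nM and 600000 nM, with some chance the read-out reports only a limit.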

Compound 4, half-maximal inhibitory concentration: 23400 nM
For compound 4 the middle estimate is 7.7-fold (0.89 log units) above the measured one; measured number below the stated range.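

In this assay, putting 3-fluorophenyl in place of 4-bromo-2-fluorophenyl gave a 2.0-fold lower number from compound 3 to compound 4 (0.31 log units; beyond the scatter), so the step did not carry over from the core of compound 1 to the core of compound 3 in either direction or size: the same change on two cores in this assay, a 5.1-fold higher number (0.71 log units; beyond the scatter) from compound 2 to compound 1 and a 2.0-fold lower number (0.31 log units; beyond the scatter) from compound 3 to compound 4, 10-fold (1.02 log units) apart, beyond the scatter of two such steps. In this series, the result of this change therefore depends on the core, at least for these two pairs. The two cores differ in more than one place, and these four compounds neither show which difference matters nor give a rule for any further core.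

From the compounds shown here alone, it remains open how an unsubstituted phenyl would behave on the ring nitrogen of each core. Also open, going by these compounds, is whether an amine or a carboxylic acid on that aryl ring would follow either pair.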